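The source may report more compounds than this note shows. Statements on the series, on what has been measured and on what is new or still open speak of the compounds shown alone.

Working notes on the series.

Of the compounds shown here, two have been measured so far. Compound 1 `Cc1cc(-c2ccsc2)c2ncc(CSCCc3ccccc3)n2c1` gives 100 ug/mL in an ADME assay on HEL cells (Homo sapiens) for cytotoxicity, with a stated time of 3 days; a lower number here means that less compound is tolerated, a higher number that more compound is tolerated. Compound 2 `COc1ccc(-c2cc(C)c3ncc(CSCCc4ccccc4)n3c2)cc1` gives 20 ug/mL in this assay and thus stands lowest of the two numbers; its nearest neighbour is compound 1, whose number is higher by a margin beyond the scatter. Among the measured compounds shown here, no pair of measured compounds differs in only one place, so the two values show no more than that less of compound 2 is tolerated than of compound 1.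

Compound 3 `Cc1cc(-c2ccccc2O)cn2c(CSCCc3ccccc3)cnc12` is not yet measured in this assay. It differs from compound 2 in a single place: 2-hydroxyphenyl in place of 4-methoxyphenyl on an aromatic carbon. For the measured compounds named here, nothing among the measured compounds tells how a change of this kind moves the minimum cytotoxic concentration. A moderate upward step is expected from compound 2 to compound 3, a 2.0-fold higher number from compound 2 to compound 3 (0.30 log units; within the scatter), but one that may fall within the scatter. Compound 3 is therefore estimated at 40 ug/mL in this assay, with a range from 15 ug/mL to 100 ug/mL.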

Compound 3, minimum cytotoxic concentration: 100 ug/mL
Estimate against measurement, compound 3: 2.5-fold (0.40 log units) below; low and high end bracket the measured number.
By their numbers in this assay, from the lowest: compound 2; then compounds 1 and 3 (each within the scatter of the next).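

In this assay, among the compounds shown here, this position, on an aromatic carbon two atoms from the ring nitrogen, gives the first reading of a change in one place: 2-hydroxyphenyl in place of 4-methoxyphenyl is a 5.0-fold higher number from compound 2 to compound 3 (0.70 log units; beyond the scatter) and so more of compound 3 is tolerated. The position is therefore not indifferent to which substituted phenyl it carries, and the minimum cytotoxic concentration moves with this exchange even though the shared core and the chain on it stay the same. The change alters two things at once, the substituent on the phenyl ring and where that substituent stands, and no measurement at hand gives a reason for the step.

From the compounds shown here alone, whether the step follows the hydroxy group or its place on the phenyl ring stays open, and 4-hydroxyphenyl and 2-methoxyphenyl at this position would separate the two. Also open, going by these compounds, is how far the number moves with a different kind of group on that phenyl ring, such as an amine or a carboxylic acid.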